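The compounds below may be only part of what the source reports. "The series", "measured", "known", "first", "only" and "open" are said of these compounds alone.

Measured so far in a functional assay on OVCAR-3 cells (Homo sapiens) for cytotoxicity, read by sulforhodamine B assay; a higher number here means a weaker inhibitor of growth, a lower number a stronger inhibitor of growth:

- Compound 1 (`COc1ccc(/C=N\NC(=S)NC(C)(C)CCC[C@](C)(O)[C@@H]2CC=C(C)CC2)cc1`): 6500 nM
- Compound 2 (`CC1=CC[C@@H]([C@@](C)(O)CCCC(C)(C)NC(=S)N/N=C\c2ccc(N(C)C)cc2)CC1`): 3600 nM
- Compound 3 (`CC1=CC[C@@H]([C@@](C)(O)CCCC(C)(C)NC(=S)N/N=C\c2ccc([N+](=O)[O-])cc2)CC1`): 13400 nM

Compound 3 has the highest number of the three and is the weakest inhibitor of growth here. Compound 4 (`CC1=CC[C@@H]([C@@](C)(O)CCCC(C)(C)NC(=S)N/N=C\c2ccc(Cl)cc2)CC1`) has chloro in place of nitro on an aromatic carbon. Among the measured compounds shown here, no chloro compound has been measured, so the nearest evidence is the two steps that introduce nitro (a 2.1-fold higher number from compound 1 to compound 3 (0.31 log units; beyond the scatter)) and (a 3.7-fold higher number from compound 2 to compound 3 (0.57 log units; beyond the scatter)). Both raised the number modestly, while the remaining step (a 1.8-fold lower number from compound 1 to compound 2 (0.26 log units; within the scatter)) stays within the scatter. Losing nitro is therefore expected to give a modest step toward a lower number in this assay, with the expected step (a 2.1-fold lower number from compound 3 to compound 4 (0.31 log units; beyond the scatter)) of similar size. Compound 4 is estimated at 6500 nM, with an expected range from 3000 nM to 13000 nM.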

Compound 4, concentration for 50% growth inhibition: 6660 nM
The estimate for compound 4 lay 1.0-fold (0.01 log units) below the measured number, and the stated range covers the measured number.
By their numbers in this assay, from the lowest: compounds 2, 1, 4 and 3 (each within the scatter of the next, the first and the last beyond it).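

In this assay chloro at this position gives a 2.0-fold lower number from compound 3 to compound 4 (0.30 log units; within the scatter) in place of nitro, a 1.9-fold higher number from compound 2 to compound 4 (0.27 log units; within the scatter) in place of dimethylamino and a 1.0-fold higher number from compound 1 to compound 4 (0.01 log units; within the scatter) in place of methoxy. Chloro, the only halogen shown here, thus cannot be told apart from any of the other three groups, although nitro stood apart from both methoxy and dimethylamino by steps beyond the scatter. Nothing measured here accounts for these steps. The compounds shown leave open how fluoro, bromo or a carboxylic acid on this aromatic carbon would read.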